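This account rests on a few compounds, and the source may have more. Where it says the series, first, only, none or still open, it means among the compounds named here.

Compound 1 `Oc1nnc(-n2cncn2)c2ccccc12` carries a 1H-1,2,4-triazol-1-yl group, and in a functional assay (trachea) with Cavia porcellus as the target (a higher number here means a weaker inhibitor, a lower number a stronger inhibitor), compound 1 gives 16600 nM. Compound 2 `CCn1nc(-n2cncn2)c2ccccc2c1=O` has a different core; the difference between the two cores is not broken down here. In this assay compound 2 gives 15800 nM, which lies within the scatter of the number for compound 1. Compound 3 `Oc1nnc(-c2nccs2)c2ccccc12` arises from compound 1 by 1,3-thiazol-2-yl in place of 1H-1,2,4-triazol-1-yl on an aromatic carbon, and in this assay compound 3 gives 4570 nM; the step is a 3.6-fold lower number from compound 1 to compound 3 (0.56 log units; beyond the scatter).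

Compound 4 `CCn1nc(-c2nccs2)c2ccccc2c1=O` has not yet been measured. It arises from compound 2 by 1,3-thiazol-2-yl in place of 1H-1,2,4-triazol-1-yl on an aromatic carbon, the same kind of change, though here the place is meta to an ethyl group and para to a group of 1 heavy atom, whereas in compound 1 it is para to a hydroxy group. This change occurs only once among the measured compounds, so the expectation rests on a single precedent. The expected step is a 3.6-fold lower number from compound 2 to compound 4 (0.56 log units; beyond the scatter), because a 3.6-fold lower number from compound 1 to compound 3 (0.56 log units; beyond the scatter) is that precedent and compound 2 with 15800 nM starts from the same level as compound 1. Compound 4 is therefore estimated at 4400 nM in this assay, with a range from 2000 nM to 10000 nM.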

Compound 4, half-maximal inhibitory concentration: 3160 nM
Estimate against measurement, compound 4: 1.4-fold (0.14 log units) above, within the range that was stated.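

Putting 1,3-thiazol-2-yl in place of 1H-1,2,4-triazol-1-yl on the core of compound 2 gives, in this assay, a 5.0-fold lower number from compound 2 to compound 4 (0.70 log units; beyond the scatter), so the change lowers the number on both cores shown, and the two steps do not differ beyond what repeated measurement would produce: the same change on two cores in this assay, a 3.6-fold lower number (0.56 log units; beyond the scatter) from compound 1 to compound 3 and a 5.0-fold lower number (0.70 log units; beyond the scatter) from compound 2 to compound 4, 1.4-fold (0.14 log units) apart, within the scatter of two such steps. Within this series, then, the change carried from one core to the other with its direction and approximate size intact. Going by these compounds alone, this rests on only two pairs of compounds, however, so it does not establish that the step would hold on a third core, and it does not explain why the number falls.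

From the compounds shown here alone, it remains open whether a phenyl ring or an amine in that place would lower the number further than the 1,3-thiazol-2-yl group does. Going by these compounds, it is also open how a longer chain, such as butyl in place of the ethyl group, would alter the number on either side of this change.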